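Methoxy-to-hydrogen step in a cytotoxicity series

The compounds below may be only part of what the source reports. "The series", "measured", "known", "first", "only" and "open" are said of these compounds alone.

Three compounds have been run in a functional assay on MDA-MB-435 cells (Homo sapiens) for cytotoxicity, read by sulforhodamine B assay, with a stated time of 48 h, tested at 1 uM; a lower number here means a stronger effect, a higher number a weaker effect of the compound at the concentration tested. Compound 1 `COc1ccc(-c2cc(/C=C/C(=O)c3ccc(N)cc3)[nH]n2)cc1` gives 85% in this assay. Compound 2 `COc1ccc(-c2cc(/C=C/C(=O)c3ccc(N)cc3)[nH]n2)cc1OC` gives 94% in this assay. Compound 3 `COc1cc(C(=O)/C=C/c2cc(-c3cc(OC)c(OC)c(OC)c3)n[nH]2)cc(OC)c1OC` gives 79% in this assay; its number is the lowest of the three, lying within the scatter of compound 1 but beyond the scatter of compound 2. The difference between the core of compound 3 and the core of compound 2 is not broken down here.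

One step between measured compounds is available: from compound 2 to compound 1 the change is hydrogen in place of methoxy on an aromatic carbon and the outcome is a number 9 percentage points lower from compound 2 to compound 1 (within the scatter).

Compound 4 `COc1ccc(-c2cc(/C=C/C(=O)c3cc(OC)c(OC)c(OC)c3)[nH]n2)cc1OC` has not been measured. It differs from compound 3 by hydrogen in place of methoxy on an aromatic carbon. This is the same kind of change as that made from compound 2 to compound 1, not the same: in compound 3 the carbon carrying the leaving methoxy is ortho to a methoxy group, meta to a large group and meta to a methoxy group, whereas in compound 2 it is ortho to a methoxy group and meta to a large group only.

Among the measured compounds shown here, the step expected here is a number 5 percentage points lower from compound 3 to compound 4 (within the scatter), which rests on the single measured instance a number 9 percentage points lower from compound 2 to compound 1 (within the scatter), a step that itself stayed within the scatter. In this assay compound 4 is therefore estimated at 74%, with a likely range from 60% to 90%.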

Compound 4, a percentage reported as activity, at one concentration (the size of the read-out at that concentration, not a potency): 85%
Beside the measured number, compound 4's estimate is 11 percentage points below it, within the range that was stated.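

In this assay, replacing methoxy with hydrogen on the core of compound 3 gives a number 6 percentage points higher from compound 3 to compound 4 (within the scatter). Carrying this change from one core to the other therefore does not give one fixed shift, and the step measured on one core is a poor guide to the step on the other: the same change on two cores in this assay, a number 9 percentage points lower (within the scatter) from compound 2 to compound 1 and a number 6 percentage points higher (within the scatter) from compound 3 to compound 4, 15 percentage points apart, beyond the scatter of two such steps This does not show that either core responds to the change on its own, since each single step stays within the scatter and only the gap between them goes beyond it; with just two instances, which also differ in the surroundings of the carbon concerned, it gives no rule for the series and no cause for the gap.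

The compounds shown leave open whether any replacement at this carbon moves the read-out beyond the scatter on either core, as only methoxy and hydrogen appear there. A hydroxyl group or a chlorine atom at the same place would test this, and the same replacement made on both cores would show whether the two steps stay apart.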